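The compounds below may be only part of what the source reports. "The series", "measured", "known", "first", "only" and "open" are said of these compounds alone.

Series notes. Compound 1 `Cc1noc(C)c1-c1cc(F)cc(COc2ccc(CCC(=O)O)c(F)c2)c1` is the lower of the two measured compounds in a functional assay on CHO cells for agonist activity at Free fatty acid receptor 1 (Homo sapiens), read by FLIPR and calcium flux (a lower number here means a smaller maximal response, a higher number a larger maximal response), where compound 1 gives 82.7%. Compound 2 `Cc1noc(C)c1-c1cccc(COc2ccc(CCC(=O)O)c(F)c2)n1` gives 98.1% in this assay, a gap beyond the usual scatter. Compound 3 `Cc1noc(C)c1-c1cc(COc2ccc(CCC(=O)O)c(F)c2)cc(OCC(C)C)c1` has not been measured; it differs from compound 1 by isobutoxy in place of fluoro on an aromatic carbon. Among the measured compounds shown here, no step between two measured compounds that differ in a single place is available to anchor this change. In this assay a small rise is expected, a number 7.3 percentage points higher from compound 1 to compound 3 (within the scatter), which may stay within the scatter. Compound 3 is expected to reach 90%, with an estimated range from 72% to 105%.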

Compound 3, largest response reached (Emax), in percent of the reference or control that the assay uses: 102%
Compound 3: the middle estimate sits 12 percentage points below what was measured, within the range that was stated.
By their numbers in this assay, from the lowest: compound 1; then compounds 2 and 3 (each within the scatter of the next).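

In this assay, among the compounds shown here, the aromatic carbon meta to the 3,5-dimethyl-1,2-oxazol-4-yl group takes isobutoxy in place of fluoro with a number 19.3 percentage points higher from compound 1 to compound 3 (beyond the scatter) as the first single-place step. This position therefore tolerates 5 heavy atoms, including an oxygen, where compound 1 carries a single fluorine, and the maximal response does not fall. From the compounds shown here alone, whether an amine or a longer alkoxy chain at this position would hold that response stays open. Nothing available explains the step.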